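This account rests on a few compounds, and the source may have more. Where it says the series, first, only, none or still open, it means among the compounds named here.

Measured so far:
Compound 1 `Cc1nc2cc(OC[C@H](O)CN3CCN(Cc4noc(-c5ccc(C(C)C)cc5)n4)CC3)ccc2s1`: 950 nM
Compound 2 `Cc1nc2cc(OC[C@H](O)CN3CCN(Cc4noc(-c5ccc(C(F)(F)F)cc5)n4)CC3)ccc2s1`: 380 nM

Both numbers come from a functional assay on mitochondria from heart for inhibition of peroxisomal acyl-coenzyme A oxidase 1 (Rattus norvegicus); on this read-out higher numbers stand for weaker inhibition and lower numbers for stronger inhibition. Compound 2 holds the lowest of the two numbers; its nearest neighbour is compound 1, and the step of a 2.5-fold lower number from compound 1 to compound 2 (0.40 log units; beyond the scatter) lies beyond the scatter. Compound 3 `Cc1nc2cc(OC[C@H](O)CN3CCN(Cc4noc(-c5ccc(Cl)c(Cl)c5)n4)CC3)ccc2s1` has not yet been measured in this assay. It differs from compound 2 in one place: 3,4-dichlorophenyl in place of 4-(trifluoromethyl)phenyl on an aromatic carbon. For the measured compounds named here, only one measured step bears on this kind of exchange, a 2.5-fold lower number from compound 1 to compound 2 (0.40 log units; beyond the scatter), a modest shift that also replaced one group with another at the far end of the molecule. That step does not compare the two groups in question directly, so it gives no firm direction. The expected step is a 1.3-fold lower number from compound 2 to compound 3 (0.10 log units; within the scatter), a change that would stay within the usual scatter. Compound 3 is therefore estimated at 300 nM, with a range from 120 nM to 800 nM.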

Compound 3, half-maximal inhibitory concentration: 550 nM
The estimate for compound 3 lay 1.8-fold (0.26 log units) below the measured number; the measured number falls inside the stated range.
By their numbers in this assay, from the lowest: compounds 2, 3 and 1 (each within the scatter of the next, the first and the last beyond it).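

In this assay the exchange of 4-(trifluoromethyl)phenyl for 3,4-dichlorophenyl on this aromatic carbon gives a 1.4-fold higher number from compound 2 to compound 3 (0.16 log units; within the scatter) and does not clearly separate the two groups. Set against 4-isopropylphenyl, the same group gives a 1.7-fold lower number from compound 1 to compound 3 (0.24 log units; within the scatter) and is not clearly separated from that group either, so compound 3 cannot be assigned to one side, although the earlier step of a 2.5-fold lower number from compound 1 to compound 2 (0.40 log units; beyond the scatter) still holds apart the two compounds that flank it. No measurement shown here explains how these groups differ in their effect. The compounds shown leave open whether an unsubstituted phenyl, or a phenyl carrying an amine or a carboxylic acid, would give a number close to these three. They also leave open whether the two chlorines act together, since neither is seen alone.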